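The source may hold more compounds than are shown below. What is called first, only, known or untested is meant among the compounds shown, and "the series" means these compounds.

Measured compounds in the series:

Compound 1 `COc1cc(-c2nnc3n2NC(c2cccs2)C(C(=O)c2ccc(C)cc2)S3)cc(OC)c1OC`, 12700 nM in a functional assay on A549 cells (Homo sapiens) for cytotoxicity, read by MTT assay, with a stated time of 48 h; on this read-out higher numbers stand for weaker inhibition and lower numbers for stronger inhibition.
Compound 3 `COc1cc(-c2nnc3n2NC(c2cccs2)C(C(=O)c2ccc(F)cc2)S3)cc(OC)c1OC`, 45000 nM in this assay.
Compound 2 `COc1cc(-c2nnc3n2NC(c2ccco2)C(C(=O)c2ccc(F)c(F)c2)S3)cc(OC)c1OC`, 93700 nM in this assay.

Compound 2 stands at the highest of the three numbers in this assay, beyond the scatter against both compound 3 and compound 1, so it is the weakest inhibitor of the set measured so far. Compound 4 `COc1cc(-c2nnc3n2NC(c2ccco2)C(C(=O)C2CC2)S3)cc(OC)c1OC` has not yet been measured. It differs from compound 2 in one place: cyclopropyl in place of 3,4-difluorophenyl on a carbonyl carbon.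

Going by the values given here, only one measured step touches the aryl ketone part of the core, a 3.5-fold higher number from compound 1 to compound 3 (0.55 log units; beyond the scatter), and that step changes a single substituent on the aromatic ring rather than removing the ring itself. Among the compounds with values here, no measured pair shows what exchanging the whole 3,4-difluorophenyl for a cyclopropyl does, so the expectation for compound 4 rests on weak ground. The one step shown indicates that this region of the structure does move the number in this assay, and compound 2 already sits at the high end, so the estimate for compound 4 is set near the value of compound 2 with a wide range, and the expected step of a 1.3-fold lower number from compound 2 to compound 4 (0.13 log units; within the scatter) is not taken to be beyond the scatter in either direction with confidence. Compound 4 is therefore estimated at 70000 nM, with a range from 15000 nM to 250000 nM.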

Compound 4, half-maximal inhibitory concentration: > 100000 nM
Compound 4 ended at the assay's limit; the forecaster's own chance of this, stated with the estimate: 25%; middle value at least 1.4-fold (0.15 log units) away from the limit.
By their numbers in this assay, from the lowest: compound 1; then compound 3; then compound 2. At a limit, above all of these: compound 4.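

In this assay, compound 4 stands at a limit of the assay, > 100000 nM, and this is a limit rather than a number. Going by these compounds alone, the only earlier step on the aryl ketone, a 3.5-fold higher number from compound 1 to compound 3 (0.55 log units; beyond the scatter), kept the aromatic ring, whereas cyclopropyl in place of 3,4-difluorophenyl on a carbonyl carbon exchanges the whole ring and gives an at least 1.0-fold higher number from compound 2 to compound 4 (0.02 log units; that floor lies within the scatter), so this change brings no lower number, while its true size stays unknown and its floor does not separate the pair beyond the scatter. The series therefore now holds a compound whose value cannot be placed exactly, and the reading of this position has to stay one-sided: the limit of > 100000 nM in this assay, at which 1 of the 4 values shown sits.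

Going by these compounds, whether an aromatic ring on the carbonyl carbon is needed at all stays open, since a phenyl without fluorine, a cyclohexyl or a longer alkyl chain at this place, with everything else as in compound 2, would be needed to tell ring size from aromatic character. Within the data shown here, compound 2 differs from compound 1 and compound 3 in more than one place, so no step linking it to them can be read.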